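The source may report more compounds than this note shows. Statements on the series, on what has been measured and on what is new or still open speak of the compounds shown alone.

Measured in an ADME assay on BHK cells (Mesocricetus auratus) for cytotoxicity, read by MTT assay, with a stated time of 96 h; a higher number here means that more compound is tolerated, a lower number that less compound is tolerated:
Compound 1 `O=[N+]([O-])c1ccc(-c2nc3ccccc3[nH]2)c([N+](=O)[O-])c1`: > 100000 nM, a limit
Compound 2 `Oc1ccc(-c2nc3cc(C(F)(F)F)ccc3[nH]2)cc1`: > 100000 nM, a limit
Compound 3 `COc1ccc(-c2nc3cc(C(F)(F)F)ccc3[nH]2)c([N+](=O)[O-])c1`: 100000 nM

Compound 2 gives only a limit, > 100000 nM, and this is the limit of > 100000 nM in this assay, at which 2 of the 3 values shown sit. Compound 4 `Fc1ccc(-c2nc3cc(C(F)(F)F)ccc3[nH]2)cc1` carries fluoro in place of hydroxy on an aromatic carbon, para to a large group (fluoro in place of hydroxy on an aromatic carbon). Going by the values given here, no measured pair shows the effect of this exchange in this assay. The expectation therefore rests on the neighbouring compound 3, which gives 100000 nM. The expected step of an at least 1.1-fold lower number from compound 2 to compound 4 (0.04 log units; that floor lies within the scatter) is small, with no clear direction and nothing beyond the scatter. For compound 4 the estimated value is 90000 nM, with an expected range from 40000 nM to 100000 nM.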

Compound 4, half-maximal cytotoxic concentration: 25000 nM
The estimate for compound 4 lay 3.6-fold (0.56 log units) above the measured number, and the stated range ends above it.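

In this assay, fluoro in place of hydroxy on this aromatic carbon gives an at least 4.0-fold lower number from compound 2 to compound 4 (0.60 log units; beyond the scatter), so this position is not indifferent to the exchange, at least in this pair. Going by these compounds, the true size of the step remains open-ended because compound 2 gives only a limit: the limit of > 100000 nM in this assay, at which 2 of the 4 values shown sit.

The compounds shown leave open whether the drop follows from the arrival of fluoro or the departure of hydroxy. They also leave open whether an amine or a chloro at the same place would stand nearer to compound 2 or to compound 4.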